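A few compounds are considered here, and "the series" means these few. Any claim that something is new, unique, unknown or untested is made for them only; others in the source may bear on it.

Compound 1 `CCCCCCCCCCCCCCCc1cc(O)cc(OC)c1O` gives 140 nM in an assay on isolated protein for inhibition of Polyunsaturated fatty acid 5-lipoxygenase (Homo sapiens), read by ELISA, with a stated time of 10 min; a higher number here means a weaker inhibitor, a lower number a stronger inhibitor. Compound 2 `CCCCCCCCCCCc1cc(O)cc(OC)c1O` gives 280 nM in this assay. The change between them is hydrogen in place of butyl on a saturated chain carbon, ten or more bonds along the chain from an aromatic carbon, and it made the step of a 2.0-fold higher number from compound 1 to compound 2 (0.30 log units; within the scatter). Compound 3 `CCCCCCCCCCCCCCCC1=CC(=O)C=C(OC)C1=O` gives 790 nM in this assay; the difference between its core and the core of compound 1 is not broken down here. Compound 4 `CCCCCCCCCCCC1=CC(=O)C=C(OC)C1=O` has not yet been measured. It differs from compound 3 by hydrogen in place of butyl on a saturated chain carbon, ten or more bonds along the chain from a double-bonded ring carbon. The place differs only in that the chain runs from a double-bonded ring carbon rather than from an aromatic carbon, so this is the same kind of change, not the same one. A step like that from compound 1 to compound 2 is expected, resting on a 2.0-fold higher number from compound 1 to compound 2 (0.30 log units; within the scatter), giving a 1.9-fold higher number from compound 3 to compound 4 (0.28 log units; within the scatter) in this assay. Compound 4 is therefore estimated at 1500 nM, in a range expected from 700 nM to 3500 nM.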

Compound 4, half-maximal inhibitory concentration: 340 nM
Compound 4: the middle estimate sits 4.4-fold (0.64 log units) above what was measured, and the stated range ends above it.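

Swapping butyl for hydrogen on the chain gave a 2.3-fold lower number from compound 3 to compound 4 (0.37 log units; beyond the scatter) in this assay, so on this core the shorter chain goes with the stronger inhibitor. Set beside the earlier step, the same change does not carry over between the two cores: the same change on two cores in this assay, a 2.0-fold higher number (0.30 log units; within the scatter) from compound 1 to compound 2 and a 2.3-fold lower number (0.37 log units; beyond the scatter) from compound 3 to compound 4, 4.6-fold (0.67 log units) apart, beyond the scatter of two such steps

Among the compounds shown here, with only one pair on each core, this shows that a step measured on one of these cores cannot simply be reused on the other, but it does not show why the two differ or how the change would behave on any further core. The compounds shown leave open whether a longer chain, or a chain ending in a carboxylic acid, would follow the step seen on either core.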